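A few compounds are considered here, and "the series" means these few. Any claim that something is new, unique, unknown or untested is made for them only; others in the source may bear on it.

Measured so far:

Compound 1, `COc1ccc(CNc2nc([SeH])nc3ccccc23)cc1`, in a functional assay on MCF7 cells (Homo sapiens) for cytotoxicity, read by MTT assay, with a stated time of 72 h; on this read-out higher numbers stand for lower toxicity in this test and lower numbers for higher toxicity in this test: > 100000 nM
Compound 2, `CCCCCSc1nc(NCc2ccc([Se]C)cc2)c2ccccc2n1`, in this assay: > 100000 nM

Both values reached are limits of the assay rather than numbers. For compound 1 the value > 100000 nM is such a limit. Within the data shown here, for compound 2 the value > 100000 nM is likewise a limit, so compound 2 stands at the edge of what this assay can report, together with the only other measured compound; this is summed up in the limit of > 100000 nM in this assay, at which 2 of the 2 values shown sit.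

Compound 3, `CSc1nc(NCc2ccc([Se]C)cc2)c2ccccc2n1`, has not yet been measured. It differs from compound 2 by one change: hydrogen in place of butyl on a saturated chain carbon bound to a sulfur. Among the measured compounds shown here, no step between measured compounds exists to guide the expectation, and compound 2 itself sits at a limit. The expected step from compound 2 to compound 3 is therefore none beyond the scatter, a step that the limit leaves unreadable from compound 2 to compound 3. Compound 3 is estimated at 150000 nM, with a range from 30000 nM to 600000 nM, most likely reported again only as a limit.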

Compound 3, concentration lethal to 50% of the cells: > 100000 nM
Compound 3: only a limit was reported; the forecaster's own chance of this, stated with the estimate: 80%; the middle value lies beyond the limit too.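

No step can be read from compound 2 to compound 3, since both results are limits and not numbers: the limit of > 100000 nM in this assay, at which 3 of the 3 values shown sit.

The compounds shown leave open which change to the structure, if any, would give a readable number in this assay.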